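From methylsulfanyl to methylsulfonyl in compound 2

This account rests on a few compounds, and the source may have more. Where it says the series, first, only, none or still open, it means among the compounds named here.

For the measured compounds named here, in a functional assay on the whole organism with Rattus norvegicus as the target (on this read-out lower numbers stand for an effect already at smaller amounts and higher numbers for an effect only at larger amounts of compound), compound 2 `CSc1cc(C)nc(Cl)c1NC(=O)N(Cc1ccc(Oc2ccc(F)cc2)cc1)C1CCCCCC1` gives 0.022 mg/kg, the only exact number among the measured compounds. Compound 1 `CSc1cc(C)nc(SC)c1NC(=O)N(Cc1cccc(Oc2ccc(Br)cc2)c1)C1CCCCCC1` gives < 0.1 mg/kg, which is a limit and not a number. Compound 3 `CSc1cc(C)nc(S(C)(=O)=O)c1NC(=O)N(Cc1ccc(Oc2ccc(F)cc2)cc1)C1CCCCCC1` gives > 0.1 mg/kg, which is also a limit.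

Compound 4 `Cc1cc(S(C)(=O)=O)c(NC(=O)N(Cc2ccc(Oc3ccc(F)cc3)cc2)C2CCCCCC2)c(Cl)n1` has not yet been measured. It keeps the chloro group of compound 2 but carries methylsulfonyl in place of methylsulfanyl on an aromatic carbon, opposite the ring nitrogen (methylsulfonyl in place of methylsulfanyl on an aromatic carbon). Going by the values given here, one measured step bears on this change: an at least 4.5-fold higher number from compound 2 to compound 3 (0.65 log units; beyond the scatter), where methylsulfonyl replaced chloro instead. That makes it an indirect guide, as the same group enters but a different group leaves. A similar move towards a higher number in this assay therefore seems more likely than no change. The expected step is a 6.8-fold higher number from compound 2 to compound 4 (0.83 log units; beyond the scatter), which would lie beyond the scatter. For compound 4 the estimated value is 0.15 mg/kg, with an expected range of 0.04 mg/kg to 0.6 mg/kg.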

Compound 4, dose for half-maximal effect: > 0.1 mg/kg
Compound 4 gave a limit, no number; the forecaster's own chance of this, stated with the estimate: 45%; the middle value does not contradict the limit.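

In this assay, methylsulfonyl in place of methylsulfanyl on the aromatic carbon opposite the ring nitrogen gives an at least 4.5-fold higher number from compound 2 to compound 4 (0.65 log units; beyond the scatter). The earlier compounds shown here showed this group entering only where compound 2 carries chloro; this result shows that the methylsulfanyl place does not accept the change without a loss either, so both measured entries of methylsulfonyl go the same way, with an at least 4.5-fold higher number from compound 2 to compound 3 (0.65 log units; beyond the scatter) as the other. How large the new step really is cannot be read, since compound 4 gives only a limit and not a number: the limit of > 0.1 mg/kg in this assay, at which 2 of the 4 values shown sit.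

The compounds shown leave open how far the number rises beyond that limit. They also leave open whether a methoxy group or an amine at this position would stay close to compound 2 at 0.022 mg/kg.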